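Extending the chloroalkyl amide chain on the shared core

The source may hold more compounds than are shown below. What is called first, only, known or untested is meant among the compounds shown, and "the series" means these compounds.

Measured compounds:
compound 1, `CC(C)c1ccccc1OS(=O)(=O)c1ccc(NC(=O)C(C)(C)C)cc1`: 11000 nM
compound 2, `CC(C)c1ccccc1OS(=O)(=O)c1ccc(NC(=O)CCl)cc1`: 1000 nM
compound 3, `CC(C)c1ccccc1OS(=O)(=O)c1ccc(NC(=O)CCCl)cc1`: 6500 nM

In a functional assay on HT-1080 cells (Homo sapiens) for antiproliferative activity, read by sulforhodamine B assay, with a stated time of 48 h (on this read-out lower numbers stand for stronger inhibition and higher numbers for weaker inhibition), compound 3 stands second highest of the three numbers: compound 1 lies within the scatter of it (a 1.7-fold lower number from compound 1 to compound 3 (0.23 log units; within the scatter)), while compound 2 lies beyond it (a 6.5-fold higher number from compound 2 to compound 3 (0.81 log units; beyond the scatter)). Compound 4, `CC(C)c1ccccc1OS(=O)(=O)c1ccc(NC(=O)CCCCl)cc1`, differs from compound 3 by chloromethyl in place of chloro on a saturated chain carbon, two bonds along the chain from a carbonyl carbon. Within the data shown here, the one measured step of the same kind, a 6.5-fold higher number from compound 2 to compound 3 (0.81 log units; beyond the scatter), lengthened the chain in the same way and weakened inhibition beyond the scatter; an 11-fold lower number from compound 1 to compound 2 (1.04 log units; beyond the scatter) shows only that the shortest chain stands apart. A further, smaller weakening is therefore expected, possibly within the scatter. Compound 4 is estimated at 10000 nM, with a range from 3500 nM to 30000 nM. The expected step is a 1.5-fold higher number from compound 3 to compound 4 (0.19 log units; within the scatter).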

Compound 4, half-maximal inhibitory concentration: 3800 nM
Beside the measured number, compound 4's estimate is 2.6-fold (0.42 log units) above it; the measured number falls inside the stated range.
By their numbers in this assay, from the lowest: compound 2; then compounds 4, 3 and 1 (each within the scatter of the next, the first and the last beyond it).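

In this assay, the step from 2-chloroethyl to 3-chloropropyl stays within the scatter (a 1.7-fold lower number from compound 3 to compound 4 (0.23 log units; within the scatter)), so the clear loss seen on the first lengthening is not repeated at this position. Compound 2 still stands apart (a 3.8-fold higher number from compound 2 to compound 4 (0.58 log units; beyond the scatter)), while the 3-chloropropyl chain, unlike the 2-chloroethyl chain, separates from the tert-butyl amide (a 2.9-fold lower number from compound 1 to compound 4 (0.46 log units; beyond the scatter)). Nothing available here accounts for these differences. The compounds shown leave open whether a longer chain ending in chlorine would stay level with compound 4. They also leave open how an amine in place of the chlorine would read.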